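The source may report more compounds than this note shows. Statements on the series, on what has been measured and on what is new or still open speak of the compounds shown alone.

Working notes on the shared core of compound 1 `Nc1cc(N)c2nc(-c3ccccc3)c(Oc3ccc(Cl)c(Cl)c3)nc2c1` and its two measured analogues, compound 2 `COc1cc(CNc2nc3cc(N)cc(N)c3nc2-c2ccccc2)cc(OC)c1OC` and compound 3 `CCOC(=O)[C@H](CCC(=O)O)NC(=O)c1ccc(Oc2nc3cc(N)cc(N)c3nc2-c2ccccc2)cc1`. In a functional assay on OVCAR-5 cells (Homo sapiens) for inhibition, read by sulforhodamine B assay, with a stated time of 48 h (a higher number here means that more compound is tolerated, a lower number that less compound is tolerated), compound 1 gives < 100000 nM, which is a limit of the assay and not a number. Compound 2 gives < 50200 nM, also a limit. Compound 3 gives < 100000 nM, again a limit. Compound 1 therefore sits at the limit of < 100000 nM in this assay, at which 2 of the 3 values shown sit, while the remaining value sits at the limit of < 50200 nM in this assay, at which 1 of the 3 values shown sits. The step under consideration leads to compound 4 `Nc1cc(N)c2nc(-c3ccccc3)c(NCc3ccc(F)cc3)nc2c1`: (4-fluorobenzyl)amino in place of 3,4-dichlorophenoxy on an aromatic carbon. Within the data shown here, no measured step in this set bears on the change, so no shift beyond the scatter is expected; the expected step is a step that the limit leaves unreadable from compound 1 to compound 4. Compound 4 is estimated at 30000 nM, with a range from 5000 nM to 100000 nM, and a limit is again quite possible.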

Compound 4, concentration lethal to 50% of the cells: < 100000 nM
Compound 4 was reported as a limit; the forecaster's own chance of this, stated with the estimate: 50%; the middle value is on the limit's open side.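

In this assay compound 4 gives < 100000 nM as a limit of the assay and not a number. Among these compounds, compound 1 also stands at a limit, so no step from compound 1 to compound 4 can be read. The compounds shown leave open how (4-fluorobenzyl)amino and 3,4-dichlorophenoxy compare on the shared core.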